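This account rests on a few compounds, and the source may have more. Where it says the series, first, only, none or still open, it means among the compounds named here.

Three close relatives of a shared core have been measured in a functional assay on SNB-75 cells (Homo sapiens) for cytotoxicity, read by sulforhodamine B assay, with a stated time of 48 h; on this read-out higher numbers stand for weaker inhibition of growth and lower numbers for stronger inhibition of growth. Compound 1 `ClCc1ccccc1Cn1cnc2c(Cl)nc(Cl)nc21` gives 1540 nM. Compound 2 `ClCc1ccccc1Cn1cnc2c(Cl)ncnc21` gives 2880 nM, and compound 3 `ClCc1cccc(Cn2cnc3c(Cl)nc(Cl)nc32)c1` gives 2040 nM. On paper the number for compound 2 is the largest of the three, but the gaps to compound 3 and to compound 1 both fall within the usual scatter of repeated measurements, so the three compounds cannot be told apart on this read-out.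

Compound 4 `Nc1nc(Cl)c2ncn(Cc3ccccc3CCl)c2n1` has not been measured. It differs from compound 2 by amino in place of hydrogen on an aromatic carbon, so an amino group replaces a hydrogen on the core.

Among the compounds with values here, only one measured step bears on this part of the core, and it concerns a different group: from compound 1 to compound 2 the change was hydrogen in place of chloro, and it gave a 1.9-fold higher number from compound 1 to compound 2 (0.27 log units; within the scatter). Within the data shown here, no measured pair shows what an amino group does here. With a single relevant step that stays within the scatter, the expectation for compound 4 in this assay is a number close to that of compound 2, with no step beyond the scatter in either direction; the step expected from compound 2 to compound 4 is a 1.2-fold lower number from compound 2 to compound 4 (0.06 log units; within the scatter). The estimate for compound 4 is therefore 2500 nM, within a range from 1000 nM to 6500 nM.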

Compound 4, concentration for 50% growth inhibition: 8130 nM
The estimate for compound 4 lay 3.3-fold (0.51 log units) below the measured number, outside the stated range (above it).
By their numbers in this assay, from the lowest: compounds 1, 3 and 2 (each within the scatter of the next); then compound 4.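

In this assay this position on the shared core, an aromatic carbon between two ring nitrogen atoms, now shows a step beyond the scatter: amino in place of hydrogen gives a 2.8-fold higher number from compound 2 to compound 4 (0.45 log units; beyond the scatter) and so moves the number toward weaker inhibition of growth, whereas the earlier swap of chloro for hydrogen at this same carbon stayed within the scatter. Amino in place of chloro gives a 5.3-fold higher number from compound 1 to compound 4 (0.72 log units; beyond the scatter) and so points the same way, which means that hydrogen and chloro cannot be told apart at this carbon, while amino stands apart from both. No measurement on these compounds accounts for this difference, and the reason for it remains unknown.

Still open, as far as these compounds go, is where other groups at this carbon would fall, such as a methylamino, a dimethylamino, a hydroxyl or a methoxy group, and whether any of them would stay with amino or return to the level of hydrogen and chloro. Also open, from the compounds shown here alone, is whether amino would bring a similar step to compound 3, which differs from compound 1 in where the chloromethyl group sits.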